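The source may report more compounds than this note shows. Statements on the series, on what has been measured and on what is new or still open speak of the compounds shown alone.

In an assay on isolated protein for inhibition of tyrosine-protein kinase receptor UFO (Homo sapiens), read by FRET and Z'-LYTE, with a stated time of 1.5 h (on this read-out higher numbers stand for weaker inhibition and lower numbers for stronger inhibition), compound 2 `Cc1c(C(=O)Nc2ccc(Oc3ncnc4[nH]cc(-c5ccccc5)c34)c(F)c2)c(=O)c2cc(C(C)C)ccc2n1C` gives 26 nM, the only number shown in the set. Compound 1 `Cc1c(C(=O)Nc2ccc(Oc3ncnc4[nH]cc(-c5ccccc5)c34)c(F)c2)c(=O)c2ccccc2n1C` reaches only a limit, > 10000 nM, which is the limit of > 10000 nM in this assay, at which 1 of the 2 values shown sits. Among the compounds with values here, the one measured step, an at least 380-fold lower number from compound 1 to compound 2 (2.58 log units; beyond the scatter), shows that the group at this carbon decides the read-out. Compound 3 `Cc1c(C(=O)Nc2ccc(Oc3ncnc4[nH]cc(-c5ccccc5)c34)c(F)c2)c(=O)c2cc(-c3ccccc3)ccc2n1C` differs from compound 2 by phenyl in place of isopropyl on an aromatic carbon. Within the data shown here, no measured step compares two such groups, so the expected change a 1.9-fold higher number from compound 2 to compound 3 (0.28 log units; within the scatter) is estimated small, near the scatter, with no firm direction. Compound 3 is therefore expected to give about 50 nM, between 10 nM and 400 nM.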

Compound 3, half-maximal inhibitory concentration: > 10000 nM
Compound 3 gave a limit, no number (the forecaster's own chance of this, stated with the estimate: 5%); middle value at least 200-fold (2.30 log units) away from the limit.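

In this assay, phenyl in place of isopropyl brings an at least 380-fold higher number from compound 2 to compound 3 (2.58 log units; beyond the scatter), so the gain seen at this carbon does not come with just any carbon group there; isopropyl gives a number and phenyl does not. Compound 3 and compound 1 both end at a limit, so the step between them cannot be read, and phenyl cannot be ranked against hydrogen: the limit of > 10000 nM in this assay, at which 2 of the 3 values shown sit.

From the compounds shown here alone, what ethyl, cyclopropyl, tert-butyl or methoxy would give at this carbon stays open. So does whether isopropyl would give a measurable number on another carbon of this ring.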